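The compounds below may be only part of what the source reports. "The series", "measured", "known", "first", "only" and "open" are said of these compounds alone.

In an in vitro ADME assay on microsomes from liver (Mus musculus) for metabolic stability, tested at 1 uM (on this read-out lower numbers stand for a shorter-lived compound and higher numbers for a longer-lived compound), three compounds built on a shared core have been measured. Compound 1 `CS(=O)(=O)CCO/N=C/c1cc(C(=O)NOCCO)c(Nc2ccc(I)cc2F)c(F)c1F` gives > 6 h, which is a limit of the assay and not a number. Compound 2 `CC(=O)NCCO/N=C/c1cc(C(=O)NOCCO)c(Nc2ccc(I)cc2F)c(F)c1F` gives > 6 h, which is also a limit. Compound 3 `O=C(NOCCO)c1cc(CN2CCOC2=O)c(F)c(F)c1Nc1ccc(I)cc1F` gives > 6 h, and this too is a limit, so the starting point of the next step is not an exact number. The whole picture so far is the limit of > 6 h in this assay, at which 3 of the 3 values shown sit.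

Compound 4 `O=C(NOCCO)c1cc(CN2OCCOC2=O)c(F)c(F)c1Nc1ccc(I)cc1F` differs from compound 3 by a single change: a group of 7 heavy atoms (3 carbon, 1 nitrogen, 3 oxygen; one six-membered non-aromatic ring with 3 hetero atoms) in place of a group of 6 heavy atoms (3 carbon, 1 nitrogen, 2 oxygen; one five-membered non-aromatic ring with 2 hetero atoms), on a saturated chain carbon bound to an aromatic carbon. The 2-oxo-1,3-oxazolidin-3-yl ring gives way to a six-membered non-aromatic ring.

Going by the values given here, three measured steps bear on this: a step that the two limits leave unreadable from compound 1 to compound 2, a step that the two limits leave unreadable from compound 1 to compound 3 and a step that the two limits leave unreadable from compound 2 to compound 3. None of them has a readable size, and none involves this exact ring swap, so they offer only weak guidance. Going by a step that the two limits leave unreadable from compound 2 to compound 3 and by the limit of > 6 h in this assay, at which 3 of the 3 values shown sit, no step beyond the usual scatter is expected in this assay, and no direction can be favoured. The expected step is a step that the limit leaves unreadable from compound 3 to compound 4. For compound 4 the estimated half-life is 7 h, with an expected range from 3.5 h to 12 h, and the assay will probably report only a limit again.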

Compound 4, half-life: 2.1 h
Estimate against measurement, compound 4: 3.3-fold (0.52 log units) above; the measured number lies below the stated range.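

In this assay, this position, a saturated chain carbon bound to an aromatic carbon, proves sensitive to the ring it carries: replacing the 2-oxo-1,3-oxazolidin-3-yl ring with the six-membered non-aromatic ring with 3 hetero atoms gives an at least 2.8-fold lower number from compound 3 to compound 4 (0.45 log units; beyond the scatter). The comparisons with the two groups that have no ring point the same way, with an at least 2.8-fold lower number from compound 2 to compound 4 (0.45 log units; beyond the scatter) and an at least 2.8-fold lower number from compound 1 to compound 4 (0.45 log units; beyond the scatter). No step among the earlier compounds can be read, so compound 4 is the first to come off the limit and give this set a readable difference: the limit of > 6 h in this assay, at which 3 of the 4 values shown sit.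

As far as these compounds go, it remains open whether the lower number goes with the larger ring, the extra ring oxygen or both; a 2-oxo-1,3-oxazinan-3-yl ring on the same carbon would help separate the two, as it has the six-membered size without that extra oxygen. From the compounds shown here alone, the full size of these steps also remains open. Compound 1, compound 2 and compound 3 are known only as limits. Each step can be stated only as a minimum.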